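Spiro-piperidine amides: acyl side-chain variation at the glycinamide

This account rests on a few compounds, and the source may have more. Where it says the series, first, only, none or still open, it means among the compounds named here.

Measured so far:
compound 1 `COC(=O)CCNC(=O)CN1CN(c2ccccc2)C2(CCN(C(=O)c3ccc(C4CCCCC4)cc3)CC2)C1=O` — 12900 nM
compound 2 `NC(=O)C1CCCN(C(=O)CN2CN(c3ccccc3)C3(CCN(C(=O)c4ccc(C5CCCCC5)cc4)CC3)C2=O)C1` — 3100 nM

Compound 2 stands lowest of the two numbers in an assay on HEK293 cells for displacement of a labelled ligand from NPC1-like intracellular cholesterol transporter 1 (Homo sapiens); a higher number here means a weaker inhibitor, a lower number a stronger inhibitor; compound 1 sits a 4.2-fold lower number from compound 1 to compound 2 (0.62 log units; beyond the scatter) away. Compound 3 `CC(C)(C)OC(=O)NCCCNC(=O)CN1CN(c2ccccc2)C2(CCN(C(=O)c3ccc(C4CCCCC4)cc3)CC2)C1=O` is not yet measured. It differs from compound 2 by (3-((tert-butoxycarbonyl)amino)propyl)amino in place of 3-carbamoylpiperidin-1-yl on a carbonyl carbon. Going by the values given here, the only step at hand is that from compound 1 to compound 2, and compound 3 returns to an open chain amide as in compound 1, so a rise back toward the number of compound 1 is expected, estimated at a 2.3-fold higher number from compound 2 to compound 3 (0.35 log units; beyond the scatter). The estimate for compound 3 is 7000 nM, within 2500 nM to 20000 nM.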

Compound 3, half-maximal inhibitory concentration: 6000 nM
Beside the measured number, compound 3's estimate is 1.2-fold (0.07 log units) above it, within the range that was stated.
By their numbers in this assay, from the lowest: compounds 2 and 3 (each within the scatter of the next); then compound 1.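

In this assay the step of a 1.9-fold higher number from compound 2 to compound 3 (0.29 log units; within the scatter) shows that an open chain on this carbonyl carbon can stand level with 3-carbamoylpiperidin-1-yl, so the ring is not required. Between the two open chains, ((tert-butoxycarbonyl)amino)methyl in place of methoxycarbonyl gives a 2.2-fold lower number from compound 1 to compound 3 (0.33 log units; beyond the scatter) here, so the chain end counts as well. No evidence at hand bears on either step. On these data alone, whether an amine or a carboxylic acid at the chain end, or a longer chain, moves the number stays open. So does which part of 3-carbamoylpiperidin-1-yl, ring or carbamoyl, carries its number.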